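Swapping a pyridinyloxy arm for a carboxymethylsulfanyl chain

A few compounds are considered here, and "the series" means these few. Any claim that something is new, unique, unknown or untested is made for them only; others in the source may bear on it.

Compound 1 `OC[C@H]1O[C@@H](n2cnc3c(COc4ccccn4)ncnc32)[C@H](O)[C@@H]1O` carries a pyridinyloxy arm on the shared core. In a functional assay on Huh-7 cells (Homo sapiens) for cytotoxicity, read by MTT assay, with a stated time of 3 days (a higher number here means that more compound is tolerated, a lower number that less compound is tolerated), compound 1 reaches only a limit of the assay, > 250000 nM, not a number. Compound 2 `CN(Cc1ccccc1)Cc1ncnc2c1ncn2[C@@H]1O[C@H](CO)[C@@H](O)[C@H]1O` gives 9000 nM in this assay. Compound 3 `O=c1ccccn1Cc1ncnc2c1ncn2[C@@H]1O[C@H](CO)[C@@H](O)[C@H]1O` again sits at a limit of this assay, > 100000 nM. Compound 4 `O=C(O)CSCc1ncnc2c1ncn2[C@@H]1O[C@H](CO)[C@@H](O)[C@H]1O` is not yet measured; it differs from compound 1 by (carboxymethyl)sulfanyl in place of (pyridin-2-yl)oxy on a saturated chain carbon bound to an aromatic carbon. Among the compounds with values here, two measured steps bear on this change: an at least 27-fold lower number from compound 1 to compound 2 (1.44 log units; beyond the scatter), while a step that the two limits leave unreadable from compound 1 to compound 3. One neighbour at this position lowered tolerance strongly and the other stayed at a ceiling, so a large step in either direction cannot be ruled out. Compound 4 is expected near 150000 nM, between 30000 nM and 300000 nM. That estimate means an at least 1.6-fold lower number from compound 1 to compound 4 (0.22 log units; that floor lies within the scatter).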

Compound 4, half-maximal cytotoxic concentration: > 100000 nM
Compound 4: a limit, no number; the forecaster's own chance of this, stated with the estimate: 55%; the middle value is on the limit's open side.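

Compound 4 gives > 100000 nM in this assay, a limit and not a number, and its steps to compound 1 and compound 3 cannot be read. Within the data shown here, the one readable step is an at least 11-fold higher number from compound 2 to compound 4 (1.04 log units; beyond the scatter). Of the four groups shown on this chain carbon, benzyl(methyl)amino alone gives a measured value, and the ring-free (carboxymethyl)sulfanyl joins the two ring-bearing groups at a limit.

From the compounds shown here alone, whether compounds 1, 3 and 4 truly differ remains open. Going by these compounds, it is also open whether the amine nitrogen or the benzyl ring of compound 2 matters, which dimethylamino and benzyloxy groups at this place could separate.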